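This account rests on a few compounds, and the source may have more. Where it says the series, first, only, none or still open, it means among the compounds named here.

In an ADME assay on HepG2 2.2.15 cells (Homo sapiens) for cytotoxicity (a lower number here means that less compound is tolerated, a higher number that more compound is tolerated), compound 3 `O=C(/C=C/c1cccnc1)OCCc1c(-c2ccccc2Cl)c2cc(Cl)ccc2[nH]c1=O` gives 39000 nM and compound 1 `O=C(OCCc1c(-c2ccccc2Cl)c2cc(Cl)ccc2[nH]c1=O)C1CCCCC1` gives 38000 nM, which is a 1.0-fold higher number from compound 1 to compound 3 (0.01 log units; within the scatter). Compound 2 `O=C(/C=C/c1cccc(F)c1)OCCc1c(-c2ccccc2Cl)c2cc(Cl)ccc2[nH]c1=O` reports only a limit, > 1600000 nM. Measured against that limit, the other steps read an at least 42-fold higher number from compound 1 to compound 2 (1.62 log units; beyond the scatter) and an at least 41-fold lower number from compound 2 to compound 3 (1.61 log units; beyond the scatter). Compound 4 `C/C=C/C(=O)OCCc1c(-c2ccccc2Cl)c2cc(Cl)ccc2[nH]c1=O` differs from compound 3 by methyl in place of pyridin-3-yl on a double-bonded chain carbon bound to a double-bonded chain carbon, with methyl in place of pyridin-3-yl on a double-bonded chain carbon bound to a double-bonded chain carbon. All three measured steps change the group on the same carbonyl carbon. Two are large, so a large upward step stays possible, but the pair of compound 1 and compound 3 shows that replacing this group need not move the number. No step beyond the scatter is therefore expected in this assay. The estimated value for compound 4 is 50000 nM, with a range of 18000 nM to 250000 nM. The expected move is a 1.3-fold higher number from compound 3 to compound 4 (0.11 log units; within the scatter).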

Compound 4, half-maximal cytotoxic concentration: 30000 nM
For compound 4 the middle estimate is 1.7-fold (0.22 log units) above the measured one, and the stated range covers the measured number.
By their numbers in this assay, from the lowest: compounds 4, 1 and 3 (each within the scatter of the next). At a limit, above all of these: compound 2.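

In this assay, methyl in place of pyridin-3-yl on the double-bonded chain carbon gives a 1.3-fold lower number from compound 3 to compound 4 (0.11 log units; within the scatter), and prop-1-en-1-yl in place of cyclohexyl on the carbonyl carbon gives a 1.3-fold lower number from compound 1 to compound 4 (0.10 log units; within the scatter). Three different groups in compound 1, compound 3 and compound 4 thus sit within the scatter of one another, and only the 3-fluorophenyl group stands apart, with an at least 53-fold lower number from compound 2 to compound 4 (1.72 log units; beyond the scatter). The number for compound 2 is a limit: the limit of > 1600000 nM in this assay, at which 1 of the 4 values shown sits.

Open, from the compounds shown here alone, is whether the fluorine or the phenyl ring carries this step. A plain phenyl group on this chain carbon would separate the two.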